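A few compounds are considered here, and "the series" means these few. Any claim that something is new, unique, unknown or untested is made for them only; others in the source may bear on it.

Working notes on the hydrazide series.

Three compounds have numbers in a functional assay on K562 cells (Homo sapiens) for inhibition, read by sulforhodamine B assay, with a stated time of 48 h; on this read-out higher numbers stand for weaker inhibition of growth and lower numbers for stronger inhibition of growth. Compound 1 `COc1ccc(C(=O)NNC(=O)c2ccc3[nH]c(-c4ccc([N+](=O)[O-])o4)nc3c2)cc1OC` gives 15.6 ug/mL. Compound 2 `O=C(NNC(=O)c1cc2ccccc2cc1O)c1ccc2[nH]c(-c3ccc([N+](=O)[O-])s3)nc2c1` gives 31.3 ug/mL. Compound 3 `COc1cc(C(=O)NNC(=O)c2ccc3[nH]c(-c4ccc([N+](=O)[O-])o4)nc3c2)cc(OC)c1OC` gives 31.3 ug/mL. Compound 1 carries the lowest of the three numbers, but its nearest and its furthest neighbours are both within the scatter of it, so no order among the three can be read from this assay. For the measured compounds named here, the one single-point step in the set, a 2.0-fold higher number from compound 1 to compound 3 (0.30 log units; within the scatter), is also within the scatter.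

The next compound, compound 4 `O=CNNC(=O)c1ccc2[nH]c(-c3ccc([N+](=O)[O-])o3)nc2c1`, has not yet been measured in this assay. Against compound 1 it differs in one place: hydrogen in place of 3,4-dimethoxyphenyl on a carbonyl carbon.

Going by the values given here, no measured step covers this change. Among the compounds with values here, the only step in hand, from compound 1 to compound 3, adds a methoxy on the aryl ring rather than removing that ring, and it was within the scatter. Loss of the whole 3,4-dimethoxyphenyl is a larger change than any compared here, so the expectation rests on the general pattern that the three measured compounds all retain an aroyl hydrazide. A higher number in this assay, by an estimated 2.2-fold higher number from compound 1 to compound 4 (0.35 log units; beyond the scatter), is expected for compound 4, with wide uncertainty. Compound 4 is therefore estimated at 35 ug/mL, in the range 12 ug/mL to 100 ug/mL.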

Compound 4, concentration for 50% growth inhibition: 31.3 ug/mL
The estimate for compound 4 lay 1.1-fold (0.05 log units) above the measured number; measured number inside the range.
By their numbers in this assay, from the lowest: compounds 1, 2, 3 and 4 (each within the scatter of the next).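

In this assay, the loss of the whole 3,4-dimethoxyphenyl, with hydrogen in its place on a carbonyl carbon, comes to a 2.0-fold higher number from compound 1 to compound 4 (0.30 log units; within the scatter) and so gives no readable change at this position. The earlier compounds shown here could not show this: compounds 1 and 3 both keep an aryl ring here and differ only by one methoxy, whereas compound 4 shows that the departure of all 10 heavy atoms of the group, one six-membered aromatic ring included, also stays within the scatter, and that a measurable number in this assay does not depend on an aryl ring at this place. The data shown offer no measurement that accounts for this result.

What the compounds shown leave open is whether any group on this carbonyl carbon can move the number beyond the scatter in either direction, for example a simple methyl, a longer alkyl chain, a primary amine or a carboxylic acid. Also open is whether the same tolerance holds on a second read-out, as only one assay is shown for these compounds.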